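From compound 3 to compound 4: a new aryl group

The source may report more compounds than this note shows. Statements on the series, on what has been measured and on what is new or still open speak of the compounds shown alone.

Measured in a functional assay on NCI-H226 cells (Homo sapiens) for inhibition, read by MTT assay, with a stated time of 48 h, tested at 10 uM; on this read-out higher numbers stand for more inhibition at the one concentration tested (going by the name of the read-out) and lower numbers for less inhibition:
compound 1, `COc1cc(NC(=O)Nc2cc(Nc3ccc(OC)c(C)c3)ncn2)cc(OC)c1`, 39.7%
compound 2, `COc1cc(NC(=O)Nc2cc(Nc3cc(I)ccc3OC)ncn2)cc(OC)c1`, 56.7%
compound 3, `COc1cc(NC(=O)Nc2cc(Nc3cc(F)ccc3OC)ncn2)cc(OC)c1`, 37.7%

Compound 3 has the lowest of the three numbers; compound 1 lies within the scatter of it, while compound 2 stands apart, as a number 19 percentage points lower from compound 2 to compound 3 (beyond the scatter) shows. Compound 4, `COc1cc(NC(=O)Nc2cc(Nc3ccc(C)c(C)c3)ncn2)cc(OC)c1`, is not yet measured. Its change from compound 3 is 3,4-dimethylphenyl in place of 5-fluoro-2-methoxyphenyl on a nitrogen on an aromatic ring. Within the data shown here, two measured steps bear on it. a number 2 percentage points lower from compound 1 to compound 3 (within the scatter) shows that exchanging the whole aryl group on that nitrogen for one without a halogen left the number within the scatter, whereas a number 19 percentage points lower from compound 2 to compound 3 (beyond the scatter) followed a change of halogen alone. Compound 4 carries no halogen and in that respect resembles compound 1. For compound 4 a step of a number 2.3 percentage points higher from compound 3 to compound 4 (within the scatter) is therefore expected, within the scatter. The estimate for compound 4 in this assay is 40%, between 26% and 54%.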

Compound 4, a percentage reported as inhibition, at one concentration (the size of the read-out at that concentration, not a potency): 45.3%
Beside the measured number, compound 4's estimate is 5.3 percentage points below it, within the range that was stated.
By their numbers in this assay, from the lowest: compounds 3, 1 and 4 (each within the scatter of the next); then compound 2.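

Replacing the whole aryl group leaves the number within the scatter, with a number 7.6 percentage points higher from compound 3 to compound 4 (within the scatter), and methyl in place of methoxy on an aromatic carbon does the same, with a number 5.6 percentage points higher from compound 1 to compound 4 (within the scatter). Only the 5-iodo-2-methoxyphenyl group stands apart from the 3,4-dimethylphenyl group, with a number 11.4 percentage points lower from compound 2 to compound 4 (beyond the scatter) as the step beyond the scatter. Nothing available explains these differences or this similarity. Still open, going by these compounds, is whether bromo or chloro in place of iodo, or an amine or a carboxylic acid on this aryl group, would move the number.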